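The compounds below may be only part of what the source reports. "The series", "measured", "known", "first", "only" and "open" are said of these compounds alone.

Measured so far in an ADME assay on CCRF-CEM cells (Homo sapiens) for antiproliferative activity, with a stated time of 48 h; on this read-out lower numbers stand for stronger inhibition and higher numbers for weaker inhibition:
- compound 1 `Nc1ccc(/C=C/C(=O)c2ccccc2)cc1`: 34000 nM
- compound 2 `Cc1ccc(C(=O)/C=C/c2ccc(N)cc2)cc1`: 31000 nM

Among the compounds with values here, compound 2 stands within the scatter of compound 1, and these are the only two numbers. Compound 3 `CCOc1ccc(C(=O)/C=C/c2ccc(N)cc2)cc1` differs from compound 2 by ethoxy in place of methyl on an aromatic carbon, para to a large group. Within the data shown here, the one measured step bearing on this is a 1.1-fold lower number from compound 1 to compound 2 (0.04 log units; within the scatter). Among the measured compounds shown here, no measured step covers ethoxy, so the range stays wide, and no step beyond the scatter is expected in this assay. The expected change is a 1.1-fold lower number from compound 2 to compound 3 (0.04 log units; within the scatter). For compound 3 the estimate is 28000 nM, with an expected range of 12000 nM to 60000 nM.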

Compound 3, half-maximal inhibitory concentration: 15000 nM
Compound 3: middle estimate off by 1.9-fold (0.27 log units), on the high side; the range from low to high includes it.
By their numbers in this assay, from the lowest: compound 3; then compounds 2 and 1 (each within the scatter of the next).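

In this assay this position, para to a large group, now shows a 2.1-fold lower number from compound 2 to compound 3 (0.32 log units; beyond the scatter) with ethoxy in place of methyl and a 2.3-fold lower number from compound 1 to compound 3 (0.36 log units; beyond the scatter) with ethoxy in place of hydrogen. Methyl in place of hydrogen stayed within the scatter, so ethoxy is the first group here to give a step beyond it, though a modest one. No measurement at hand explains this step.

Open, as far as these compounds go, is whether the oxygen or the chain carries the step: methoxy or propoxy would separate the two. An amine or a carboxylic acid on this carbon would test other kinds of group.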